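This account rests on a few compounds, and the source may have more. Where it says the series, first, only, none or still open, it means among the compounds named here.

Working notes on the series. Among the measured compounds shown here, compound 2 `O=C(NO)c1ccc(Cn2ccc3cc(C(=O)c4ccc(Cl)cc4)ccc32)cc1` gives 6.73 nM in an assay on isolated protein for inhibition of protein deacetylase HDAC6 (Homo sapiens) (a lower number here means a stronger inhibitor, a higher number a weaker inhibitor), which is the highest of the two numbers so far; the nearest is compound 1 `COc1ccc(C(=O)c2ccc3c(ccn3Cc3ccc(C(=O)NO)cc3)c2)cc1`, which gives 3.92 nM, and the step of a 1.7-fold higher number from compound 1 to compound 2 (0.23 log units; within the scatter) stays within the scatter. Compound 3 `COc1cccc(C(=O)c2ccc3c(ccn3Cc3ccc(C(=O)NO)cc3)c2)c1` has not yet been measured in this assay. Its difference from compound 2 is 3-methoxyphenyl in place of 4-chlorophenyl on a carbonyl carbon. For the measured compounds named here, the only measured step that bears on this position is the one from compound 1 to compound 2, where chloro in place of methoxy on an aromatic carbon left the number within the scatter; no measured step shows the effect of 3-methoxyphenyl itself. On that basis no step beyond the scatter is expected, so the estimated step is a 1.2-fold lower number from compound 2 to compound 3 (0.09 log units; within the scatter). Compound 3 is accordingly expected at about 5.5 nM, with a range from 2 nM to 16 nM.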

Compound 3, half-maximal inhibitory concentration: 16.4 nM
Beside the measured number, compound 3's estimate is 3.0-fold (0.47 log units) below it; measured number outside the range, above it.
By their numbers in this assay, from the lowest: compounds 1 and 2 (each within the scatter of the next); then compound 3.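

In this assay, among the compounds shown here, this position proves sensitive for the first time: replacing 4-methoxyphenyl with 3-methoxyphenyl gives a 4.2-fold higher number from compound 1 to compound 3 (0.62 log units; beyond the scatter) and so moves the number beyond the scatter with the same group count and the same methoxy substituent. Set against 4-chlorophenyl, the same group gives a 2.4-fold higher number from compound 2 to compound 3 (0.39 log units; beyond the scatter) as a modest step, so the tolerance seen between compound 1 and compound 2 does not extend to compound 3. Nothing available here explains these steps.

The compounds shown leave open whether chloro placed as in 3-methoxyphenyl would follow methoxy, which would separate the place of the substituent from its identity. They also leave open how an unsubstituted phenyl, an amine or a carboxylic acid would read on this ring.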